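A few compounds are considered here, and "the series" means these few. Any claim that something is new, unique, unknown or untested is made for them only; others in the source may bear on it.

Compound 1 `Nc1ccccc1NC(=O)c1ccc(CNCc2nc(-c3ccc(C(F)(F)F)cc3)no2)cc1`: 6870 nM
Compound 2 `Nc1ccccc1NC(=O)c1ccc(CNCc2nc(-c3ccc(Cl)cc3)no2)cc1`: 5120 nM

In a functional assay on MDA-MB-231 cells (Homo sapiens) for inhibition, read by MTT assay, with a stated time of 72 h (a higher number here means a weaker inhibitor, a lower number a stronger inhibitor), compound 2 stands at 5120 nM and lies within the usual scatter of compound 1 at 6870 nM so these two measurements cannot be told apart.

Compound 3 `Nc1ccccc1NC(=O)c1ccc(CNCc2nc(-c3ccc(F)cc3)no2)cc1` keeps the shared core and differs from compound 2 in a single group. The change is fluoro in place of chloro on an aromatic carbon and in words it is fluoro in place of chloro on an aromatic carbon, para to a large group.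

For the measured compounds named here, one measured step bears on this, also a swap of one group on an aromatic carbon: a 1.3-fold lower number from compound 1 to compound 2 (0.13 log units; within the scatter) and it stayed within the scatter. Going by the values given here, with that small step as the only guide, no change beyond the scatter is expected in this assay and no direction can be called. The expected step is a 1.1-fold higher number from compound 2 to compound 3 (0.03 log units; within the scatter) and it remains only an estimate. Compound 3 is expected at 5500 nM with an estimated range from 2800 nM to 11000 nM in this measurement.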

Compound 3, half-maximal inhibitory concentration: 2950 nM
Beside the measured number, compound 3's estimate is 1.9-fold (0.27 log units) above it; the measured number falls inside the stated range.
By their numbers in this assay, from the lowest: compounds 3, 2 and 1 (each within the scatter of the next, the first and the last beyond it).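

In this assay, the exchange of chloro for fluoro gives a 1.7-fold lower number from compound 2 to compound 3 (0.24 log units; within the scatter) and so cannot, on its own, be told apart from repeat-measurement noise. Set against the trifluoromethyl group, however, fluoro gives a 2.3-fold lower number from compound 1 to compound 3 (0.37 log units; beyond the scatter) and this is the first step in the series to clear the scatter, showing that the group at this position can shift the cell result, though only modestly, with chloro falling within the scatter of both neighbours. Nothing measured here accounts for that shift.

As far as these compounds go, all three compounds carry fluorine or chlorine at this position, so it remains open how a plain hydrogen, a methyl, a methoxy, an amine or a carboxylic acid would read there. From the compounds shown here alone, whether the small shift seen here holds on other cell lines also remains open.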